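Aryl ether glycoside series: isopropyl variant and cytotoxicity outlook

The source may report more compounds than this note shows. Statements on the series, on what has been measured and on what is new or still open speak of the compounds shown alone.

Working notes on the series. All members share one core; compound 1 `CO[C@@H]1O[C@H](COc2ccc(-c3ccccc3)cc2)[C@@H](O)[C@H](O)[C@H]1Oc1ccccc1` carries a plain phenoxy group on it. In a functional assay on MDA-MB-231 cells (Homo sapiens) for cytotoxicity, read by MTT assay, with a stated time of 48 h (a lower number here means that less compound is needed, a higher number that more compound is needed for the effect), compound 1 gives "not determined" (no result reported), so it stands nowhere on the numbers and no value can be given for it. Among the compounds with values here, compound 2 `CO[C@@H]1O[C@H](COc2ccc(-c3ccccc3)cc2)[C@@H](O)[C@H](O)[C@H]1Oc1ccc(OC2CCCCC2)cc1` is the single member with a number: in this assay compound 2 gives 36000 nM, a weak effect. Compound 3 `CO[C@@H]1O[C@H](COc2ccc(-c3ccccc3)cc2)[C@@H](O)[C@H](O)[C@H]1Oc1cccc(C(C)C)c1` is not yet measured. It differs from compound 1 by isopropyl in place of hydrogen on an aromatic carbon. Since compound 1 has no value, the size of the step from compound 1 to compound 3 cannot be read from any measured pair, and the only anchor in the series is the value of compound 2. The expectation is therefore that compound 3 lands in the same weak range as compound 2, with no step beyond the usual scatter expected from that level. For compound 3 in this assay the estimated value is 30000 nM, expected to fall between 10000 nM and 90000 nM.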

Compound 3, half-maximal effective concentration: 35000 nM
Compound 3: the middle estimate sits 1.2-fold (0.07 log units) below what was measured; low and high end bracket the measured number.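

In this assay, within the data shown here, compound 1 gives "not determined" (no result reported) and so no step from compound 1 to compound 3 can be read. The compounds shown leave open what isopropyl in place of hydrogen on the aromatic carbon does to the effect. No measured property is at hand that bears on this result.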